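The compounds below may be only part of what the source reports. "The series", "measured", "known", "first", "only" and "open" are said of these compounds alone.

Compound 1 `Cc1cc(C)c(S(=O)(=O)N2CCC(N3CC(C)CC(C)C3)CC2)c(C)c1` and compound 2 `CCCC(=O)NC1CCN(S(=O)(=O)c2c(C)cc(C)cc2C)CC1` share one core and differ only in the group carried on a saturated ring carbon. In a functional assay on DLD-1 cells (Homo sapiens) for antiproliferative activity, read by CellTiter-Glo, with a stated time of 72 h (on this read-out higher numbers stand for weaker inhibition and lower numbers for stronger inhibition), compound 1 gives 17 nM. In this assay compound 2 gives > 5000 nM, which is a limit of the measurement and not a number. Compound 2 therefore stands at the limit of > 5000 nM in this assay, at which 1 of the 2 values shown sits. Among the measured compounds shown here, the single measured step, an at least 290-fold higher number from compound 1 to compound 2 (2.46 log units; beyond the scatter), shows that putting (propylcarbonyl)amino in place of the 3,5-dimethylpiperidin-1-yl wiped out nearly all of the inhibition. Compound 3 `Cc1cc(C)c(S(=O)(=O)N2CCC(N3CCC(O)CC3)CC2)c(C)c1` brings a ring back to that carbon: 4-hydroxypiperidin-1-yl in place of (propylcarbonyl)amino on a saturated ring carbon. For the measured compounds named here, the one measured step that bears on this change was large, so a large step back toward stronger inhibition is expected, an at least 33-fold lower number from compound 2 to compound 3 (1.52 log units; beyond the scatter). Compound 3 is accordingly estimated to give 150 nM in this assay, with a likely range from 30 nM to 1500 nM.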

Compound 3, half-maximal inhibitory concentration: 106 nM
Compound 3: the middle estimate sits 1.4-fold (0.15 log units) above what was measured; the range from low to high includes it.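

Putting a ring back on this saturated ring carbon restores much of the inhibition in this assay, with an at least 47-fold lower number from compound 2 to compound 3 (1.67 log units; beyond the scatter), so strong inhibition does not depend on the two methyl groups of 3,5-dimethylpiperidin-1-yl. The two rings are still not interchangeable, since 4-hydroxypiperidin-1-yl in place of 3,5-dimethylpiperidin-1-yl gives a 6.2-fold higher number from compound 1 to compound 3 (0.79 log units; beyond the scatter), a modest step beside the large one on leaving (propylcarbonyl)amino. The first of these steps has only a lower bound, as the value of compound 2 is a limit of the measurement and not a number: the limit of > 5000 nM in this assay, at which 1 of the 3 values shown sits.

Going by these compounds, compound 1 and compound 3 differ in the methyl groups and the hydroxy group at once, so the share of each in their gap stays open. Also open, on these data alone, is how an unsubstituted piperidin-1-yl ring or an open-chain amine such as diethylamino would compare.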